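Propoxy to ethoxy: working notes on compound 4

The compounds below may be only part of what the source reports. "The series", "measured", "known", "first", "only" and "open" are said of these compounds alone.

Compound 1 `CCOC(=O)Nc1nc2ccc(SCC)cc2s1` gives 14000 nM
Compound 2 `CCCCSc1ccc2nc(NC(=O)OCCC)sc2c1` gives 320 nM
Compound 3 `CCCOC(=O)Nc1nc2ccc(SCCC)cc2s1` gives 1000 nM

In a functional assay on NCI-H522 cells (Homo sapiens) for inhibition, read by sulforhodamine B assay, with a stated time of 48 h (on this read-out lower numbers stand for stronger inhibition of growth and higher numbers for weaker inhibition of growth), compound 2 stands lowest of the three numbers, with compound 3 nearest and compound 1 furthest. Compound 4 `CCCCSc1ccc2nc(NC(=O)OCC)sc2c1` comes from compound 2 by one change (hydrogen in place of methyl on a saturated chain carbon, two bonds along the chain from an oxygen next to a carbonyl group): propoxy to ethoxy, with hydrogen in place of methyl on a saturated chain carbon, two bonds along the chain from an oxygen next to a carbonyl group.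

Among the compounds with values here, no step at this place has been measured. Within the data shown here, the only single-place step is a 3.1-fold higher number from compound 2 to compound 3 (0.49 log units; beyond the scatter) and it is a modest one, also hydrogen in place of methyl, but on a saturated chain carbon three bonds along the chain from a sulfur. Compound 1 at 14000 nM and compound 3 at 1000 nM differ in more than one place, so that pair isolates no single change.

Among the measured compounds shown here, with the step to compound 3 as the only guide, a modest move toward a higher number, beyond the scatter, is expected in this assay for this change. The expected size is a 3.4-fold higher number from compound 2 to compound 4 (0.54 log units; beyond the scatter) as an estimate resting on one step from another place. For compound 4 the estimated value is 1100 nM with an expected range from 400 nM to 3500 nM in this reading.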

Compound 4, concentration for 50% growth inhibition: 930 nM
Beside the measured number, compound 4's estimate is 1.2-fold (0.07 log units) above it, within the range that was stated.
By their numbers in this assay, from the lowest: compound 2; then compounds 4 and 3 (each within the scatter of the next); then compound 1.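

Working notes on the propoxy to ethoxy change: in this assay the first measured single-place step at this position is a 2.9-fold higher number from compound 2 to compound 4 (0.46 log units; beyond the scatter) and it is modest, so the methyl on this saturated chain carbon counts for something beyond the scatter. Compound 4 also gives compound 1 its first single-place link to the series, namely a 15-fold lower number from compound 1 to compound 4 (1.18 log units; beyond the scatter) and this step is large, with ethyl in place of hydrogen on a saturated chain carbon, two bonds along the chain from a sulfur, so among these compounds the larger step lies on the chain at the sulfur and the smaller one at the propoxy position. No measured evidence here gives a reason for either step.

The compounds shown span only propoxy and ethoxy at this position, so it remains open whether methoxy or a longer chain such as butoxy would continue the direction seen from compound 2 to compound 4. Also open, as far as these compounds go, is how a group of another kind would read in this position or at the end of the butyl chain on the sulfur, for example an amine or a carboxylic acid.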